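Same Atoms, Stereocentres Left Undrawn

A few compounds are considered here, and "the series" means these few. Any claim that something is new, unique, unknown or untested is made for them only; others in the source may bear on it.

Measured so far:
compound 1 `COc1cc([C@H]2Oc3c(OC)cc(/C=C/C=O)cc3[C@@H]2CO)cc(OC)c1O`: 88700 nM
compound 2 `COc1cc([C@@H]2Oc3c(OC)cc(/C=C/C=O)cc3[C@H]2CO)ccc1O`: 38700 nM

In a functional assay on HepG2 cells (Homo sapiens) for cytotoxicity, read by MTT assay, with a stated time of 48 h (on this read-out higher numbers stand for weaker inhibition and lower numbers for stronger inhibition), compound 1 gives 88700 nM, the highest of the two numbers. Compound 2 gives 38700 nM, a lower number beyond the scatter. Compound 3 `COc1cc(C2Oc3c(OC)cc(/C=C/C=O)cc3C2CO)cc(OC)c1O` has not been measured. It differs from compound 1 as follows: the two compounds have the same atoms and bonds; at least one stereo element is drawn with a configuration in one of them and without one in the other: 2 of 3 stereo elements differ; a stereocentre at a saturated ring carbon is drawn S in compound 1 and without a configuration in compound 3; a stereocentre at a saturated ring carbon is drawn R in compound 1 and without a configuration in compound 3. For the measured compounds named here, no step between measured compounds is available, so compound 3 is expected to sit close to compound 1, with a step of a 1.0-fold lower number from compound 1 to compound 3 (0.00 log units; within the scatter) not beyond the scatter. For compound 3 the estimate is 88000 nM, within a range from 40000 nM to 190000 nM.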

Compound 3, half-maximal inhibitory concentration: 80500 nM
Beside the measured number, compound 3's estimate is 1.1-fold (0.04 log units) above it; measured number inside the range.
By their numbers in this assay, from the lowest: compound 2; then compounds 3 and 1 (each within the scatter of the next).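

In this assay, leaving both saturated ring carbons without a drawn configuration comes with a 1.1-fold lower number from compound 1 to compound 3 (0.04 log units; within the scatter), so this read-out does not separate the two compounds. This is the first comparison of compounds that differ in one place, and the only thing that separates them is this: the fact that one of compounds 1 and 3 is drawn with a defined configuration and the other without, at the place where they differ

The compounds shown leave open whether the opposite configuration at these two carbons on the core of compound 1 would give a different number. They also leave open how an amine or a carboxylic acid on the shared core would read here.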